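This account rests on a few compounds, and the source may have more. Where it says the series, first, only, none or still open, it means among the compounds named here.

Compound 1 `CCCCCC(CCO)n1cnc2c(NC)ncnc21`: > 50000 nM
Compound 2 `CCCCCCCCCCC(CCO)n1cnc2c(NC)ncnc21`: 12700 nM
Compound 3 `CCCCCCCCCCCC(CCO)n1cnc2c(NC)ncnc21`: not yet measured

In a functional assay on HCT-116 cells (Homo sapiens) for antiproliferative activity, read by MTT assay, with a stated time of 48 h (a lower number here means a stronger inhibitor, a higher number a weaker inhibitor), compound 1 stands at > 50000 nM, which is a limit of the assay and not a number. Among the measured compounds shown here, compound 2 gives 12700 nM, the only true number so far, so there is no series of numbers to place it in.

Compound 3 extends the chain of compound 2: methyl in place of hydrogen on a saturated chain carbon, ten or more bonds along the chain from an aromatic nitrogen. In words, this is methyl in place of hydrogen on a saturated chain carbon, ten or more bonds along the chain from an aromatic nitrogen.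

For the measured compounds named here, only one measured step bears on this change, a longer extension of the same chain, pentyl in place of hydrogen: an at least 3.9-fold lower number from compound 1 to compound 2 (0.59 log units; beyond the scatter). Going by these compounds, it starts from a limit, so its full size is unknown. Methyl is a much smaller addition than pentyl, so a much smaller step in the same direction, towards a lower number in this assay, is expected, probably within the scatter. The expected change is a 1.3-fold lower number from compound 2 to compound 3 (0.10 log units; within the scatter). For compound 3 the estimate is 10000 nM, with an expected range of 5000 nM to 20000 nM.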

Compound 3, half-maximal inhibitory concentration: 15400 nM
The estimate for compound 3 lay 1.5-fold (0.19 log units) below the measured number; the measured number falls inside the stated range.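

In this assay, methyl in place of hydrogen on a saturated chain carbon, ten or more bonds along the chain from an aromatic nitrogen, gives a 1.2-fold higher number from compound 2 to compound 3 (0.08 log units; within the scatter), so this one extra carbon brings no change that can be told from the scatter. Among the compounds shown here, the earlier step, with its much larger pentyl addition, could not show this, and it is the first sign that lengthening the chain need not keep lowering the number. Hexyl in place of hydrogen, six bonds along the chain from an aromatic nitrogen, gives an at least 3.2-fold lower number from compound 1 to compound 3 (0.51 log units; beyond the scatter), and the value of compound 1 in that step is a limit of the assay and not a number, so the full size of the step stays unknown: the limit of > 50000 nM in this assay, at which 1 of the 3 values shown sits.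

Open, going by these compounds, is how chains longer than that of compound 1 but shorter than that of compound 2 behave, and whether a still longer chain than that of compound 3 would move the number at all. Also open, on these data alone, is what an amine or a carboxylic acid in place of the methyl would do in this assay.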